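A few compounds are considered here, and "the series" means these few. Any claim that something is new, unique, unknown or untested is made for them only; others in the source may bear on it.

Compound 1, `Cc1cn([C@H]2C[C@H](SSc3ccccc3[N+](=O)[O-])[C@@H](CO)O2)c(=O)[nH]c1=O`: in a physicochemical assay for metabolic stability, in the presence of a further agent that is not named here (on this read-out lower numbers stand for a shorter-lived compound and higher numbers for a longer-lived compound), compound 1 gives < 0.167 h, which is a limit of the assay and not a number.
Compound 2, `CCCCSS[C@H]1C[C@H](n2cc(C)c(=O)[nH]c2=O)O[C@@H]1CO`: in this assay compound 2 gives < 8 h, again a limit of the assay.
Compound 3, `Cc1cn([C@H]2C[C@H](SSCCN)[C@@H](CO)O2)c(=O)[nH]c1=O`: in this assay compound 3 gives < 8 h, also a limit of the assay.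

Compound 3 therefore stands at a limit rather than at a number, and so do the two other compounds, as the limit of < 0.167 h in this assay, at which 1 of the 3 values shown sits, and the limit of < 8 h in this assay, at which 2 of the 3 values shown sit, show. Compound 4, `Cc1cn([C@H]2C[C@H](SSCCCCCCO)[C@@H](CO)O2)c(=O)[nH]c1=O`, differs from compound 3 by 4-hydroxybutyl in place of amino on a saturated chain carbon, two bonds along the chain from a sulfur. The measured step closest to this change, on the same chain carbon, is a step that the two limits leave unreadable from compound 2 to compound 3; the step that the two limits leave unreadable from compound 1 to compound 3 is equally unreadable. Neither yields a size or a direction, so no step beyond the scatter can be foreseen. For compound 4 in this assay the expected value is 6 h, with a range from 1 h to 24 h. As a step, that expectation reads a step that the limit leaves unreadable from compound 3 to compound 4.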

Compound 4, half-life: < 8 h
Compound 4 ended at the assay's limit; the forecaster's own chance of this, stated with the estimate: 70%; the middle value does not contradict the limit.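

Within the data shown here, compound 4, like compound 1, compound 2 and compound 3, stands at a limit in this assay, so no step among them can be read. The compounds shown leave open how the group on the sulfur affects the half-life.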